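Replacing One Furan on a Pyridine-Type Core

The source may hold more compounds than are shown below. What is called first, only, known or untested is meant among the compounds shown, and "the series" means these compounds.

In a functional assay on HCT-15 cells (Homo sapiens) for cytotoxicity, read by ELISA, with a stated time of 4 days (a lower number here means a stronger inhibitor, a higher number a weaker inhibitor), compound 1 (`Clc1ccc(-c2cc(-c3ccoc3)cc(-c3ccco3)n2)s1`) gives 1280 nM and compound 2 (`Cc1cccc(-c2cc(-c3ccoc3)cc(-c3ccc(Cl)s3)n2)c1`) gives 880 nM so the two stand level within the usual scatter. Compound 3 (`Clc1ccc(-c2cc(-c3ccco3)nc(-c3ccc(Cl)s3)c2)o1`) is not yet measured and differs from compound 1 by 5-chlorofuran-2-yl in place of furan-3-yl on an aromatic carbon opposite the ring nitrogen. Among the compounds with values here, the only measured step (a 1.5-fold lower number from compound 1 to compound 2 (0.16 log units; within the scatter)) replaces furan-2-yl rather than furan-3-yl, so it bears only indirectly and points to no clear direction. No shift beyond the scatter is expected in this assay and the estimated 1.2-fold lower number from compound 1 to compound 3 (0.07 log units; within the scatter) is correspondingly small. For compound 3 1100 nM is the estimated value with 350 nM to 3500 nM as the expected range.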

Compound 3, half-maximal inhibitory concentration: > 50000 nM
Compound 3: only a limit was reported (the forecaster's own chance of this, stated with the estimate: 5%); middle value at least 45-fold (1.65 log units) from the limit.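

Within the data shown here, the position opposite the ring nitrogen proves sensitive: in this assay, 5-chlorofuran-2-yl in place of furan-3-yl gives an at least 39-fold higher number from compound 1 to compound 3 (1.59 log units; beyond the scatter), whereas the only earlier step, made at another position, stayed within the scatter. A higher number means a weaker inhibitor, so this single change costs much of the activity. For compound 3 the reported figure is a limit, not a number: the limit of > 50000 nM in this assay, at which 1 of the 3 values shown sits.

The compounds shown do not separate the effect of the chlorine from that of the changed furan attachment. Going by these compounds, how an unsubstituted furan-2-yl, an amine or a carboxylic acid would behave at this position also stays open.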